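Shortening the side chain on the shared core

This account rests on a few compounds, and the source may have more. Where it says the series, first, only, none or still open, it means among the compounds named here.

The series shares one core, varied at a saturated chain carbon bound to an amine nitrogen. In a functional assay on cells for antagonist activity at C-X-C chemokine receptor type 4 (Homo sapiens), read by fluorescence and calcium flux, with stated times of 25 min and 90 s (on this read-out lower numbers stand for stronger inhibition and higher numbers for weaker inhibition), compound 3 `c1ccc2c(c1)CN[C@@H](CN(CCCCNCC1CCCCC1)[C@H]1CCCc3cccnc31)C2` gives 158 nM, the lowest of the two numbers shown. Compound 1 `c1ccc2c(c1)CN[C@@H](CN(CCCCN(Cc1ccncc1)Cc1ccncc1)[C@H]1CCCc3cccnc31)C2` gives 832 nM in this assay, a gap from compound 3 that lies beyond the scatter. Compound 2 `c1ccc(CN(CCCCN(C[C@H]2Cc3ccccc3CN2)[C@H]2CCCc3cccnc32)Cc2ccccc2)cc1` reaches only a limit in this assay, > 16700 nM, as noted in the limit of > 16700 nM in this assay, at which 1 of the 3 values shown sits. Compound 4 `NCc1ccccc1CN(C[C@H]1Cc2ccccc2CN1)[C@H]1CCCc2cccnc21` is not yet measured and carries 2-(aminomethyl)phenyl in place of 3-((cyclohexylmethyl)amino)propyl on a saturated chain carbon bound to an amine nitrogen. No measured step of this kind exists among the compounds shown. A weakening beyond the scatter is nonetheless expected, with the estimated step of a 19-fold higher number from compound 3 to compound 4 (1.28 log units; beyond the scatter). Compound 4 is expected to give 3000 nM, within 700 nM to 15000 nM.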

Compound 4, half-maximal inhibitory concentration: 50.8 nM
The estimate for compound 4 lay 59-fold (1.77 log units) above the measured number; measured number below the stated range.
By their numbers in this assay, from the lowest: compound 4; then compound 3; then compound 1. At a limit, above all of these: compound 2.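

At a saturated chain carbon bound to an amine nitrogen, 2-(aminomethyl)phenyl in place of 3-((cyclohexylmethyl)amino)propyl gives a 3.1-fold lower number from compound 3 to compound 4 (0.49 log units; beyond the scatter) in this assay. This position therefore does not depend on the cyclohexyl ring and accepts a six-membered aromatic ring of carbon only. The entering group is also the smaller one by its count of heavy atoms, so the larger group is not required here.

As far as these compounds go, whether a hydroxymethyl or a carboxylic acid could replace the aminomethyl on the phenyl ring and keep this number remains open. Nothing measured here gives a reason for the step.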